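Swapping a ring on a thiocarbonyl carbon

A few compounds are considered here, and "the series" means these few. Any claim that something is new, unique, unknown or untested is made for them only; others in the source may bear on it.

Compound 1 `COc1ccc(CN(C(=O)CSc2nc3ccccc3o2)c2cc(OC)c(OC)c(OC)c2)cc1`: 3280 nM
Compound 2 `CCN1CCN(C(=S)SCC(=O)N(Cc2ccc(OC)cc2)c2cc(OC)c(OC)c(OC)c2)CC1`: 7700 nM

In a functional assay on HCT-116 cells (Homo sapiens) for inhibition, read by CCK-8 assay, with a stated time of 48 h (a higher number here means a weaker inhibitor, a lower number a stronger inhibitor), compound 2 gives 7700 nM, the higher of the two numbers, which makes it the weaker inhibitor of the pair. Compound 3 `COc1ccc(CN(C(=O)CSC(=S)N2CCOCC2)c2cc(OC)c(OC)c(OC)c2)cc1` is the next to consider. It carries morpholin-4-yl in place of 4-ethylpiperazin-1-yl on a thiocarbonyl carbon, and the rest of the structure stays the same: morpholin-4-yl in place of 4-ethylpiperazin-1-yl on a thiocarbonyl carbon. Both groups are six-membered non-aromatic rings.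

Among the compounds with values here, no measured step tests this exchange directly. Within the data shown here, the only step available is a 2.3-fold higher number from compound 1 to compound 2 (0.37 log units; beyond the scatter), a modest one. It swapped a different pair of groups on a sulfur, so it only hints at how much a change in this part of the molecule can matter. A swap between two rings of the same size is therefore expected to give a step no larger than that one, and the data offer no firm direction. The expected change is small: a 1.2-fold lower number from compound 2 to compound 3 (0.07 log units; within the scatter). For compound 3 the estimated value in this assay is 6500 nM, with an expected range of 2800 nM to 15000 nM.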

Compound 3, half-maximal inhibitory concentration: 4130 nM
The estimate for compound 3 lay 1.6-fold (0.20 log units) above the measured number; the measured number falls inside the stated range.
By their numbers in this assay, from the lowest: compounds 1, 3 and 2 (each within the scatter of the next, the first and the last beyond it).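

In this assay, the exchange of 4-ethylpiperazin-1-yl for morpholin-4-yl on a thiocarbonyl carbon gives a 1.9-fold lower number from compound 2 to compound 3 (0.27 log units; within the scatter), so this pair of six-membered rings cannot be told apart at this position, even though the ring that enters has fewer heavy atoms and an oxygen in place of a nitrogen. The comparison with the compound that has no thiocarbonyl group gives a 1.3-fold higher number from compound 1 to compound 3 (0.10 log units; within the scatter), which means that replacing the group on the sulfur does not always produce a difference beyond the scatter, as the earlier step between compound 1 and compound 2 might have suggested; compound 3 has the new kind of group on the sulfur and still cannot be separated from compound 1. No measurement accompanies these numbers that could say why the values fall as they do.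

The compounds shown leave open whether a piperidine ring, a piperazine with a free ring amine, or an open diethylamino group on the same thiocarbonyl carbon would stay within this narrow band. They also leave open whether any ring at this position can bring a step beyond the scatter in either direction.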